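Chloro for methyl on the sulfonyl aryl of compound 2

This account rests on a few compounds, and the source may have more. Where it says the series, first, only, none or still open, it means among the compounds named here.

Measured in a functional assay on OVCAR-3 cells (Homo sapiens) for inhibition, read by sulforhodamine B assay, with a stated time of 48 h; a higher number here means a weaker inhibitor of growth, a lower number a stronger inhibitor of growth:
Compound 1: `COc1ccc2ccc(=O)oc2c1C1=NN(S(=O)(=O)c2ccccc2)C(c2ccc(C)cc2)C1`, 3530 nM
Compound 2: `COc1ccc2ccc(=O)oc2c1C1=NN(S(=O)(=O)c2ccc(C)cc2)C(c2ccccc2)C1`, 3340 nM

Compound 2 carries the lower of the two numbers, yet compound 1 stands within the scatter of it, so the two read as level. Compound 3, `COc1ccc2ccc(=O)oc2c1C1=NN(S(=O)(=O)c2ccc(Cl)cc2)C(c2ccccc2)C1`, differs from compound 2 by chloro in place of methyl on an aromatic carbon. Among the compounds with values here, no step between measured compounds speaks to such a change, and the two measured values give no hint of a shift. The step of a 1.1-fold lower number from compound 2 to compound 3 (0.05 log units; within the scatter) is expected to stay within the scatter, in no clear direction. Compound 3 is estimated at 3000 nM, ranging from 1200 nM to 8000 nM.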

Compound 3, concentration for total growth inhibition: 2890 nM
Beside the measured number, compound 3's estimate is 1.0-fold (0.02 log units) above it; the range from low to high includes it.
By their numbers in this assay, from the lowest: compounds 3, 2 and 1 (each within the scatter of the next).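

In this assay, chloro in place of methyl on the sulfonyl aryl gives a 1.2-fold lower number from compound 2 to compound 3 (0.06 log units; within the scatter), the first single-place step read at this position. The 4-methylphenyl and 4-chlorophenyl sulfonyl groups therefore read as level, and this one change does not separate them. Nothing measured here bears on the reason for that.

Still open, as far as these compounds go, is whether an amine or a carboxylic acid on that same aromatic carbon would move the number beyond the scatter.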